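Changing the aryl group on the sulfonyl sulfur

This account rests on a few compounds, and the source may have more. Where it says the series, first, only, none or still open, it means among the compounds named here.

Compound 1 `CCN(CC)c1ccc2cc(C(=O)c3ccc(N4CCN(C(=O)COc5ccc(Cl)cc5Cl)CC4)cc3)oc2c1`: 5730 nM in a functional assay on A549 cells (Homo sapiens) for cytotoxicity, read by MTT assay, with a stated time of 48 h; a lower number here means a stronger inhibitor, a higher number a weaker inhibitor
Compound 2 `CCN(CC)c1ccc2cc(C(=O)c3ccc(N4CCN(S(=O)(=O)c5ccc(C(F)(F)F)cc5)CC4)cc3)oc2c1`: 11100 nM in this assay

Compound 2 holds the highest of these two numbers, though its gap to compound 1 lies within the usual scatter, so the two cannot be ordered. Compound 3 `CCN(CC)c1ccc2cc(C(=O)c3ccc(N4CCN(S(=O)(=O)c5ccc(Br)c(F)c5)CC4)cc3)oc2c1` differs from compound 2 by 4-bromo-3-fluorophenyl in place of 4-(trifluoromethyl)phenyl on a sulfonyl sulfur. For the measured compounds named here, no measured pair shows this kind of exchange, so nothing known points either way. The step from compound 2 to compound 3 is therefore expected to be a 1.1-fold lower number from compound 2 to compound 3 (0.05 log units; within the scatter), no change beyond the scatter. For compound 3 the estimate in this assay is 10000 nM, with a range from 4000 nM to 30000 nM.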

Compound 3, half-maximal inhibitory concentration: 15100 nM
Estimate against measurement, compound 3: 1.5-fold (0.18 log units) below, and the stated range covers the measured number.
By their numbers in this assay, from the lowest: compounds 1, 2 and 3 (each within the scatter of the next, the first and the last beyond it).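

In this assay, for the compounds shown here, 4-bromo-3-fluorophenyl in place of 4-(trifluoromethyl)phenyl on a sulfonyl sulfur gives a 1.4-fold higher number from compound 2 to compound 3 (0.13 log units; within the scatter), so the two aryl groups cannot be told apart at this position. (4-Bromo-3-fluorophenyl)sulfonyl in place of ((2,4-dichlorophenoxy)methyl)carbonyl on an amine nitrogen in a ring gives a 2.6-fold higher number from compound 1 to compound 3 (0.42 log units; beyond the scatter), the first step here beyond the scatter. Nothing available accounts for either step. Still open, on these data alone, is how the number would move with an amine or a carboxylic acid on the aryl ring, or with a simple alkyl chain on the sulfonyl sulfur.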